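The compounds below may be only part of what the source reports. "The series", "measured", "known", "first", "only" and "open" are said of these compounds alone.

Compound 1 `O=C(O)Cc1sc(C(c2ccc(F)cc2)c2ccc(F)cc2)nc1-c1ccoc1` carries a furan-3-yl group on the shared core. In an in vitro functional assay on HEK285-7 cells for antagonist activity at prostaglandin D2 receptor 2 (Homo sapiens), read by BRET and beta-arrestin recruitment (a lower number here means a smaller maximal response, a higher number a larger maximal response), compound 1 gives 80%. Compound 2 `O=C(O)Cc1sc(C(c2ccccc2)c2ccc(Cl)cc2)nc1-c1ccc(Cl)cc1` gives 80% in this assay, and compound 3 `COc1ccc(C(c2ccccn2)c2nc(-c3ccc(Cl)cc3)c(CC(=O)O)s2)cc1` gives 80%. Compound 1 thus stands level with compound 2 and with compound 3 at the digits shown, all three lying within the usual scatter of one another. Compound 4 `O=C(O)Cc1sc(C(c2ccc(F)cc2)c2ccc(F)cc2)nc1-c1ccnc(O)c1` has not yet been measured. It differs from compound 1 in a single place: 2-hydroxypyridin-4-yl in place of furan-3-yl on an aromatic carbon. Among the compounds with values here, no measured pair shows this change, so no measured guide exists. Because compound 1 gives 80%, the largest response of compound 4 is expected to stay close to it. The step of no change at the digits printed from compound 1 to compound 4 (within the scatter) is expected to be no larger than the scatter, in either direction. Compound 4 is estimated at 80%, between 62% and 95%.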

Compound 4, largest response reached (reported as efficacy), in percent of the reference or control that the assay uses: 60%
Estimate against measurement, compound 4: 20 percentage points above; measured number outside the range, below it.
By their numbers in this assay, from the lowest: compound 4; then compounds 1, 2 and 3 (each within the scatter of the next).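

In this assay, within the data shown here, 2-hydroxypyridin-4-yl in place of furan-3-yl gives a number 20 percentage points lower from compound 1 to compound 4 (beyond the scatter), the first single-place step in this set. It shows that the group on this aromatic carbon, next to the ring nitrogen, can change the largest response, which the three earlier compounds, differing from one another in more than one place, could not show. No measurement shown gives a reason for this step. Going by these compounds, whether the hydroxy group or the six-membered ring goes with the lower number stays open. A plain pyridin-4-yl or phenyl group at this position would help separate the two.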